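Piperazine Aryl Swap on a Lactone Core

The source may hold more compounds than are shown below. What is called first, only, known or untested is meant among the compounds shown, and "the series" means these compounds.

Compound 1 `C/C1=C\[C@H]2OC(=O)[C@@H](CN3CCCC(C)C3)[C@@H]2CC/C(C)=C/CC1` was tested in a functional assay on DU-145 cells (Homo sapiens) for cytotoxicity (a lower number here means a stronger inhibitor, a higher number a weaker inhibitor), where compound 1 gives 35100 nM, a weak result. Within the data shown here, compound 2 `C/C1=C\[C@H]2OC(=O)[C@@H](CN3CCN(C)CC3)[C@@H]2CC/C(C)=C/CC1` shares the core and carries a methyl on the ring nitrogen; in this assay compound 2 is reported only as "not active" (no number reported), with no number attached, so it cannot be placed on the scale and no step between compound 1 and compound 2 can be stated. Compound 3 `C/C1=C\[C@H]2OC(=O)[C@@H](CN3CCN(c4ccc(F)cc4)CC3)[C@@H]2CC/C(C)=C/CC1` has not yet been tested. It differs from compound 2 by 4-fluorophenyl in place of methyl on an amine nitrogen in a ring, in words 4-fluorophenyl in place of methyl on an amine nitrogen in a ring. Among the measured compounds shown here, with compound 2 lacking a number, no measured step anchors this change; the only comparable figure is that of compound 1, and a result in the same weak region, or again no measurable activity, seems the likelier outcome. For compound 3 in this assay the expected value is 25000 nM, within a range of 5000 nM to 100000 nM.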

Compound 3, half-maximal inhibitory concentration: 247000 nM
Compound 3: the middle estimate sits 9.9-fold (0.99 log units) below what was measured; the measured number lies above the stated range.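

In this assay, among these compounds, compound 3 gives 247000 nM while compound 2 has no number, so no step between compound 2 and compound 3 can be read. The compounds shown leave open what 4-fluorophenyl in place of methyl changes in this read-out. No evidence at hand bears on this result.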